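From hydroxy to methoxy in compound 1

The compounds below may be only part of what the source reports. "The series", "measured", "known", "first", "only" and "open" are said of these compounds alone.

Measured so far in a functional assay on OVCAR-5 cells (Homo sapiens) for antiproliferative activity, read by sulforhodamine B assay, with a stated time of 48 h; a lower number here means a stronger inhibitor, a higher number a weaker inhibitor:
compound 1 `O=C(NCCCNc1cc(-c2cn(-c3ccccc3)nc2-c2cccc(O)c2)ccn1)Nc1ccc(F)cc1`: 3370 nM
compound 2 `O=C(NCCCNc1cc(-c2cn(-c3ccccc3)nc2-c2cccc(O)c2)ccn1)Nc1cccc(C(F)(F)F)c1`: 3960 nM

Compound 1 has a single measured neighbour, compound 2, and the two values lie within the scatter of each other, so neither stands apart in this assay. Among the measured compounds shown here, the only measured step is a 1.2-fold higher number from compound 1 to compound 2 (0.07 log units; within the scatter), with 3-(trifluoromethyl)phenyl in place of 4-fluorophenyl on an amide-type nitrogen, and it stays within the scatter.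

Next comes compound 3 `COc1cccc(-c2nn(-c3ccccc3)cc2-c2ccnc(NCCCNC(=O)Nc3ccc(F)cc3)c2)c1`, which keeps the core of compound 1 and differs in one place: methyl in place of hydrogen on an oxygen on an aromatic ring, that is, 3-methoxyphenyl in place of 3-hydroxyphenyl. For the measured compounds named here, the measured step lies elsewhere on the structure, so it bears on this change only indirectly, and no measured pair varies the hydroxy group. The central expectation is therefore no shift beyond the scatter, in either direction, held with a wide margin. The estimated step is a 1.1-fold higher number from compound 1 to compound 3 (0.05 log units; within the scatter). For compound 3 the expected value is 3800 nM, with an estimated range from 1500 nM to 9000 nM.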

Compound 3, half-maximal inhibitory concentration: 11200 nM
The estimate for compound 3 lay 2.9-fold (0.47 log units) below the measured number, outside the stated range (above it).
By their numbers in this assay, from the lowest: compounds 1 and 2 (each within the scatter of the next); then compound 3.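

In this assay, among the compounds shown here, the 3-hydroxyphenyl position responds to substitution on its oxygen: methoxy in place of hydroxy gives a 3.3-fold higher number from compound 1 to compound 3 (0.52 log units; beyond the scatter), a step beyond the scatter, whereas the only earlier step, a 1.2-fold higher number from compound 1 to compound 2 (0.07 log units; within the scatter), changed the aryl group on the amide-type nitrogen and stayed within the scatter. Within this single pair, the free hydroxy carries the lower number, so this is the first change in the series to separate two compounds in this assay. No supporting measurement bears on the origin of this step, so the pair fixes its size and direction but not its explanation.

The compounds shown leave open whether the step follows from losing the hydrogen on the oxygen or from adding the methyl; an amine or a fluorine in place of the hydroxy, or a longer ethoxy group, would help separate the two readings. From the compounds shown here alone, it also remains open whether the same step would appear with the 3-(trifluoromethyl)phenyl group of compound 2, so the result applies for now only to the 4-fluorophenyl pair.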